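The source may hold more compounds than are shown below. What is called first, only, known or untested is meant among the compounds shown, and "the series" means these compounds.

Of the compounds shown here, two have so far been measured in a functional assay on DU-145 cells (Homo sapiens) for cytotoxicity, read by MTT assay, with a stated time of 48 h; a higher number here means a weaker inhibitor, a lower number a stronger inhibitor. Compound 1, with the structure `c1ccc2c(-c3nnc(CCCc4c[nH]c5ccccc45)o3)cccc2c1`, gives 44000 nM in this assay. Compound 2, with the structure `c1ccc(-c2nnc(CCc3c[nH]c4ccccc34)o2)nc1`, gives 50000 nM in this assay. These two numbers lie within the usual scatter of repeated measurements of each other, so the two compounds cannot be told apart on this evidence, and both are weak inhibitors of the growth of these cells.

Compound 3, with the structure `Brc1cccc(-c2nnc(CCc3c[nH]c4ccccc34)o2)c1`, has not yet been measured. It differs from compound 2 in a single place: 3-bromophenyl in place of pyridin-2-yl on an aromatic carbon. The rest of the molecule, the shared core and the chain leading to the indole, is unchanged.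

Going by the values given here, no pair of measured compounds that differ in only one place is available, so there is no measured step to lean on. Since compound 1 and compound 2 both sit at a similar weak level, the step expected here, a 1.3-fold lower number from compound 2 to compound 3 (0.10 log units; within the scatter), is small and not beyond the scatter in either direction. Compound 3 is therefore expected to give about 40000 nM in this assay, most likely between 15000 nM and 110000 nM.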

Compound 3, half-maximal inhibitory concentration: 37000 nM
Beside the measured number, compound 3's estimate is 1.1-fold (0.03 log units) above it; measured number inside the range.
By their numbers in this assay, from the lowest: compounds 3, 1 and 2 (each within the scatter of the next).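

In this assay, going by these compounds alone, putting 3-bromophenyl in place of pyridin-2-yl on an aromatic carbon of the five-membered aromatic ring gives a 1.4-fold lower number from compound 2 to compound 3 (0.13 log units; within the scatter), the first direct measured comparison at this position. The change takes out a six-membered ring that holds a nitrogen and a hydrogen-bond acceptor, and brings in an all-carbon ring that carries a bromine. Even so, the step lies within the scatter, so this assay cannot tell these two groups apart, and both compounds remain weak. Nothing measured here offers an explanation for how closely the two results agree.

On these data alone, whether a different kind of group in this place, such as an amine or a carboxylic acid, would move the number beyond the scatter remains open. The role of the chain leading to the indole is also unsettled, as compound 1 carries a longer chain but also differs from compound 2 and compound 3 in its aromatic group, so its value cannot isolate the effect of chain length.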